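Swapping fluoro for cyano in compound 2

The compounds below may be only part of what the source reports. "The series", "measured", "known", "first", "only" and "open" are said of these compounds alone.

Compound 1 `CCN(CC)Cc1cc(Nc2nc3ccccc3[nH]2)ccc1O` gives > 50000 nM (a limit of the assay, not a number)
Compound 2 `CCN(CC)Cc1cc(Nc2nc3ccccc3n2Cc2ccc(F)cc2)ccc1O` gives 12000 nM

Both compounds were tested in an ADME assay on CHO cells (Cricetulus griseus) for inhibition, read by MTT assay; on this read-out lower numbers stand for stronger inhibition and higher numbers for weaker inhibition. Going by the values given here, compound 2 holds the only true number so far, 12000 nM. The result for compound 1 is a limit of the assay. Among the compounds with values here, the one measured step is an at least 4.1-fold lower number from compound 1 to compound 2 (0.61 log units; beyond the scatter). Compound 3 `CCN(CC)Cc1cc(Nc2nc3ccccc3n2Cc2ccc(C#N)cc2)ccc1O` keeps the frame of compound 2 and changes only the group at the end of the benzyl arm: cyano in place of fluoro on an aromatic carbon. In words, this is cyano in place of fluoro on an aromatic carbon, para to a large group, or 4-fluorobenzyl to 4-cyanobenzyl. Within the data shown here, the measured step added that whole arm, whereas this change only swaps its end group, and no measured step makes this swap. That step therefore offers only a loose guide, and no change beyond the scatter is expected. The expected step is a 1.1-fold higher number from compound 2 to compound 3 (0.03 log units; within the scatter). Compound 3 is estimated at 13000 nM, with an expected range of 5000 nM to 32000 nM.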

Compound 3, half-maximal inhibitory concentration: > 50000 nM
Compound 3 ended at the assay's limit; the forecaster's own chance of this, stated with the estimate: 10%; at least 3.8-fold (0.58 log units) between middle value and limit.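

Compound 3 in this assay gives > 50000 nM, which is a limit of the assay and not a true number. Even so, cyano in place of fluoro at the end of the benzyl arm gives an at least 4.1-fold higher number from compound 2 to compound 3 (0.61 log units; beyond the scatter), so the arm alone does not set the number of compound 2: the group at its end counts as well, which the earlier step could not show. The step between compound 1 and compound 3 cannot be read, because both compounds end at the same limit: the limit of > 50000 nM in this assay, at which 2 of the 3 values shown sit.

From the compounds shown here alone, how large the change from fluoro to cyano really is stays open. Also open, going by these compounds, is whether chloro, methoxy or an amine at this place would keep the number of compound 2 or lose it.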